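The source may hold more compounds than are shown below. What is called first, only, known or untested is meant among the compounds shown, and "the series" means these compounds.

Values in a functional assay for inhibition, with Homo sapiens as the target (a higher number here means weaker binding, a lower number tighter binding), for the measured members of the series:

compound 1 `O=C(O)CC/C=C\CC1COC(c2ccco2)OC1c1cccnc1`: 1260 nM
compound 2 `O=C(O)CC/C=C\CC1COC(c2cccc3ccccc23)OC1c1cccnc1`: 631 nM
compound 3 `Cc1ccc(OC(C)(C)C2OCC(C/C=C\CCC(=O)O)C(c3cccnc3)O2)cc1`: 631 nM

Compound 3 stands level with compound 2 at the digits given, and these two share the lowest numbers of the three. The nearest neighbour of compound 3 is compound 2, with no change at the digits given; the furthest is compound 1, and the gap between the number of compound 3 and that of compound 1 lies within the scatter. Among the compounds with values here, no step is drawn between these two, so only their two values speak.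

Within the data shown here, the one step that has been measured is a 2.0-fold lower number from compound 1 to compound 2 (0.30 log units; within the scatter), which concerns a saturated ring carbon and stays within the scatter.

Compound 4 `CC(C)(Cc1ccc(F)cc1)C1OCC(C/C=C\CCC(=O)O)C(c2cccnc2)O1` differs from compound 3 by 4-fluorobenzyl in place of 4-methylphenoxy on a saturated chain carbon bound to two saturated chain carbons and a saturated ring carbon. Among the measured compounds shown here, no measured step touches this saturated chain carbon, so nothing bears directly on the change; the only step seen, at another position, stayed within the scatter. The expectation is therefore no step beyond the scatter, a 1.0-fold lower number from compound 3 to compound 4 (0.00 log units; within the scatter), and compound 4 is expected to give 630 nM, with a range from 250 nM to 1600 nM in this assay.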

Compound 4, dissociation constant: 89.1 nM
Beside the measured number, compound 4's estimate is 7.1-fold (0.85 log units) above it; measured number below the stated range.
By their numbers in this assay, from the lowest: compound 4; then compounds 2, 3 and 1 (each within the scatter of the next).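

In this assay, within the data shown here, the saturated chain carbon bound to two saturated chain carbons and a saturated ring carbon carries the only step beyond the scatter: with 4-fluorobenzyl in place of 4-methylphenoxy, the data show a 7.1-fold lower number from compound 3 to compound 4 (0.85 log units; beyond the scatter) at this position. The exchange keeps the count of 8 heavy atoms and the six-membered aromatic ring of carbon only, yet the entering group holds 1 fluorine and 0 hydrogen-bond acceptors where the leaving group holds 1 oxygen and 1 hydrogen-bond acceptor, so the number responds to a change that leaves these counts of size and ring type as they were. Nothing available accounts for the step.

The exchange alters both the link to the aromatic ring and the substituent on it, so the compounds shown do not separate the two; 4-methylbenzyl and 4-fluorophenoxy on this carbon would. From the compounds shown here alone, it also stays open whether the step holds with naphthalen-1-yl or furan-2-yl on the saturated ring carbon, or whether an amine on the aromatic ring in place of fluorine gives a similar number.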